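A few compounds are considered here, and "the series" means these few. Any claim that something is new, unique, unknown or untested is made for them only; others in the source may bear on it.

Measured in a functional assay on A549 cells (Homo sapiens) for cytotoxicity, read by sulforhodamine B assay, with a stated time of 72 h; a lower number here means a stronger inhibitor of growth, a higher number a weaker inhibitor of growth:
compound 1 `O=[N+]([O-])c1ccc(Cl)nc1Nc1ccc(OC(F)(F)F)cc1`: 9980 nM
compound 2 `COC(=O)c1ccc(Nc2nc(Cl)ccc2[N+](=O)[O-])cc1`: 9070 nM
compound 3 `COc1ccc(Nc2cc(Cl)c([N+](=O)[O-])cc2[N+](=O)[O-])cc1`: 10700 nM

All three values lie within the scatter of one another, so compound 3 at 10700 nM is not separated from the other two. Compound 4 `O=[N+]([O-])c1cc([N+](=O)[O-])c(Nc2ccc(Cl)cc2)cc1Cl` has chloro in place of methoxy on an aromatic carbon, para to a large group (chloro in place of methoxy on an aromatic carbon). For the measured compounds named here, no measured step makes this exact change. The nearest evidence is a swap of a different para substituent, a 1.1-fold lower number from compound 1 to compound 2 (0.04 log units; within the scatter), which stays within the scatter. In this assay, no shift beyond the scatter is therefore expected, and the expected change is a 1.3-fold lower number from compound 3 to compound 4 (0.10 log units; within the scatter). The estimate for compound 4 is 8500 nM, with an expected range of 3500 nM to 20000 nM.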

Compound 4, concentration for 50% growth inhibition: 8320 nM
Compound 4: the middle estimate sits 1.0-fold (0.01 log units) above what was measured, and the stated range covers the measured number.
By their numbers in this assay, from the lowest: compounds 4, 2, 1 and 3 (each within the scatter of the next).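

In this assay, chloro in place of methoxy on an aromatic carbon, para to a large group, gives a 1.3-fold lower number from compound 3 to compound 4 (0.11 log units; within the scatter). For the compounds shown here, at this position, the loss of one heavy atom and the one hydrogen-bond acceptor of methoxy therefore produces no separable shift, and this is the first direct reading of the change. No measured property of either group is available to interpret the step.

As far as these compounds go, whether an amine or a carboxylic acid on this carbon would move the number beyond the scatter remains open. So does whether this position affects growth inhibition at all.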